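Fluoro in place of hydrogen on compound 2

The source may hold more compounds than are shown below. What is called first, only, known or untested is meant among the compounds shown, and "the series" means these compounds.

Measured so far in an in vivo ADME assay on the whole organism (strain Sprague-Dawley) for pharmacokinetics, with Rattus norvegicus as the target (a lower number here means slower removal, a higher number faster removal of the compound), for this series:
- compound 1 `O=C1NC(=O)C(c2ccc(-c3ccc4ccccc4c3)[nH]c2=O)O1` gives 31 mL/min/kg here
- compound 2 `CC(C)C1(c2ccc(-c3ccc4ccccc4c3)[nH]c2=O)OC(=O)NC1=O` gives 2.6 mL/min/kg here
- compound 3 `CC(C)C1(c2ccc(-c3ccc4c(ccn4C)c3)[nH]c2=O)OC(=O)NC1=O` gives 4.5 mL/min/kg here

Compound 2 at 2.6 mL/min/kg sits within the scatter of compound 3 at 4.5 mL/min/kg and far from compound 1. Compound 4 `CC(C)C1(c2ccc(-c3ccc4cccc(F)c4c3)[nH]c2=O)OC(=O)NC1=O` carries one change from compound 2, fluoro in place of hydrogen on an aromatic carbon (fluoro in place of hydrogen on an aromatic carbon, ortho to a fused ring and meta to a fused ring). Among the measured compounds shown here, the only measured step in one place is large, a 12-fold lower number from compound 1 to compound 2 (1.08 log units; beyond the scatter) for isopropyl in place of hydrogen on a saturated ring carbon, but it concerns a different change. For the measured compounds named here, no measured step covers fluoro in place of hydrogen, so no shift beyond the scatter is expected in this assay and no direction is favoured. An estimated 1.2-fold higher number from compound 2 to compound 4 (0.06 log units; within the scatter) is expected to stay within the scatter. For compound 4 the estimate is 3 mL/min/kg with an expected range of 1.5 mL/min/kg to 6 mL/min/kg in this series.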

Compound 4, clearance: 2.8 mL/min/kg
Compound 4: the middle estimate sits 1.1-fold (0.03 log units) above what was measured; measured number inside the range.
By their numbers in this assay, from the lowest: compounds 2, 4 and 3 (each within the scatter of the next); then compound 1.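

In this assay, fluoro in place of hydrogen on an aromatic carbon, ortho to a fused ring and meta to a fused ring, gives a 1.1-fold higher number from compound 2 to compound 4 (0.03 log units; within the scatter), so this aromatic carbon accepts the change without a shift beyond the scatter. Unlike the earlier step, which was at a saturated ring carbon, this one tests the aromatic part of compound 2. No measurement in hand bears on the reason for this result. Open, from the compounds shown here alone, is whether a methoxy group or an amine on this same carbon would leave the number as undisturbed, and whether fluoro on other aromatic carbons would do the same.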